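The compounds below may be only part of what the source reports. "The series", "measured", "known", "first", "only" and "open" are said of these compounds alone.

Measured compounds in the series:
- compound 1 `Cc1ccccc1NS(=O)(=O)c1ccc(N2CCNC2=O)cc1` — 200 nM
- compound 2 `O=C1NCCN1c1ccc(S(=O)(=O)Nc2ccc(Br)cc2)cc1` — 300 nM
- compound 3 `COc1cccc(NS(=O)(=O)c2ccc(N3CCNC3=O)cc2)c1` — 120 nM

All three share one core and differ only in the aryl group on the sulfonamide nitrogen. In a functional assay on HT-29 cells (Homo sapiens) for antiproliferative activity, read by sulforhodamine B assay, with a stated time of 48 h (a lower number here means a stronger inhibitor, a higher number a weaker inhibitor), compound 3 gives 120 nM and has the lowest number of the three, but the gap to compound 1, a 1.7-fold lower number from compound 1 to compound 3 (0.22 log units; within the scatter), is within the scatter, so compound 3 and compound 1 cannot be separated. Against compound 2 the gap is a 2.5-fold lower number from compound 2 to compound 3 (0.40 log units; beyond the scatter), a modest step beyond the scatter. The step of a 1.5-fold higher number from compound 1 to compound 2 (0.18 log units; within the scatter) is within the scatter.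

Compound 4 `CCc1cccc(NS(=O)(=O)c2ccc(N3CCNC3=O)cc2)c1` is not yet measured. It differs from compound 3 by ethyl in place of methoxy on an aromatic carbon, placed on an aromatic carbon of a six-membered aromatic ring of carbon only, meta to a large group.

For the measured compounds named here, no measured step isolates an ethyl against a methoxy; each recorded step swaps the whole aryl group at once, and all such swaps fall within or just beyond the scatter. The three values span a narrow window, so a small step, if any, is expected for compound 4, with no clear direction. The expected step is a 1.3-fold higher number from compound 3 to compound 4 (0.10 log units; within the scatter). In this assay compound 4 is estimated at 150 nM, within a range of 60 nM to 400 nM.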

Compound 4, half-maximal inhibitory concentration: 110 nM
Beside the measured number, compound 4's estimate is 1.4-fold (0.13 log units) above it; the range from low to high includes it.
By their numbers in this assay, from the lowest: compounds 4, 3, 1 and 2 (each within the scatter of the next, the first and the last beyond it).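

In this assay, ethyl in place of methoxy on this aromatic carbon gives a 1.1-fold lower number from compound 3 to compound 4 (0.04 log units; within the scatter), so compound 3 and compound 4 cannot be separated, and the count of one hydrogen-bond acceptor on the leaving methoxy against none on ethyl leaves no readable mark on the number. The wider comparison stays as flat: a 1.8-fold lower number from compound 1 to compound 4 (0.26 log units; within the scatter) also lies within the scatter, whereas a 2.7-fold lower number from compound 2 to compound 4 (0.44 log units; beyond the scatter) is a modest step beyond it, so compound 3 and compound 4 both stand apart from compound 2, while compound 1 does not. Nothing at hand bears on why methoxy and ethyl read alike here.

The compounds shown hold only methoxy and ethyl at this place, each of 2 heavy atoms, so how a longer chain, an amine or a carboxylic acid there would read in this assay remains open. Also open, going by these compounds, is whether the gap to compound 2 belongs to the bromine or to where it sits, since 4-bromophenyl differs from 3-ethylphenyl in both group and place.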